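The compounds below may be only part of what the source reports. "The series", "measured", "known", "first", "only" and "open" are said of these compounds alone.

Measured so far in a functional assay on HCT-116 cells (Homo sapiens) for antiproliferative activity, read by MTT assay, with a stated time of 72 h; a lower number here means a stronger inhibitor, a higher number a weaker inhibitor:
- compound 1 `CCCCc1cn(C[C@H](O)[C@H]2OC(=O)C(OCc3ccccc3)=C2OCc2ccccc2)nn1`: 10400 nM
- compound 2 `COc1ccccc1-c1cn(C[C@H](O)[C@H]2OC(=O)C(OCc3ccccc3)=C2OCc2ccccc2)nn1`: > 100000 nM

Compound 2 is known only as a limit of this assay, (the limit of > 100000 nM in this assay, at which 1 of the 2 values shown sits); no number stands for it. Within the data shown here, the single measured step, an at least 9.6-fold higher number from compound 1 to compound 2 (0.98 log units; beyond the scatter), concerns a different replacement and so gives little direct guidance.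

Compound 3 `O=C1O[C@H]([C@@H](O)Cn2cc(CNS(=O)(=O)c3ccc(F)cc3)nn2)C(OCc2ccccc2)=C1OCc1ccccc1` differs from compound 2 by (((4-fluorophenyl)sulfonyl)amino)methyl in place of 2-methoxyphenyl on an aromatic carbon. With compound 2 at a limit, any step from it can only be guessed against compound 1. Compound 3 is expected to give 30000 nM, in the range 8000 nM to 100000 nM. This corresponds to an expected step of an at least 3.3-fold lower number from compound 2 to compound 3 (0.52 log units; beyond the scatter), with a fair chance that only a limit is again reported.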

Compound 3, half-maximal inhibitory concentration: 22900 nM
Compound 3: the middle estimate sits 1.3-fold (0.12 log units) above what was measured; measured number inside the range.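

In this assay compound 2 stands only as a limit, so its step is a bound. At this aromatic carbon, (((4-fluorophenyl)sulfonyl)amino)methyl in place of 2-methoxyphenyl brings a measured number, with an at least 4.3-fold lower number from compound 2 to compound 3 (0.64 log units; beyond the scatter) as that bound. The same group still falls short of the butyl chain, with a 2.2-fold higher number from compound 1 to compound 3 (0.34 log units; beyond the scatter) beyond the scatter, so neither aromatic-bearing group shown matches butyl here. Open, from the compounds shown here alone, is whether a longer alkyl chain than butyl would go further at this carbon. Also open, going by these compounds, is how a simple amine or carboxylic acid there would compare.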